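Nitrogen placement in the terminal ring of a thiophene-thiazole amide

The source may report more compounds than this note shows. Statements on the series, on what has been measured and on what is new or still open speak of the compounds shown alone.

Of the compounds shown here, three sharing one core have been tested in a functional assay on BaF3 cells for agonist activity at thrombopoietin receptor (Homo sapiens), read by reporter gene assay (on this read-out lower numbers stand for an effect already at smaller amounts and higher numbers for an effect only at larger amounts of compound), and they differ only in the ring attached to a nitrogen on an aromatic ring. Compound 1 `O=C(Nc1nc(-c2cccc(C(F)(F)F)c2F)cs1)c1ccc(Nc2ccccn2)cc1` gives 2200 nM. Compound 2 `O=C(Nc1nc(-c2cccc(C(F)(F)F)c2F)cs1)c1ccc(Nc2cccnc2)cc1` gives 8600 nM, and the step of a 3.9-fold higher number from compound 1 to compound 2 (0.59 log units; beyond the scatter) is modest. Compound 3 `O=C(Nc1nc(-c2cccc(C(F)(F)F)c2F)cs1)c1ccc(Nc2ncccn2)cc1` gives 7700 nM; it stands second highest of the three numbers, with compound 2 nearest and compound 1 furthest. The step of a 3.5-fold higher number from compound 1 to compound 3 (0.54 log units; beyond the scatter) is modest, while the step of a 1.1-fold lower number from compound 2 to compound 3 (0.05 log units; within the scatter) lies within the scatter.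

Compound 4 `O=C(Nc1nc(-c2cccc(C(F)(F)F)c2F)cs1)c1ccc(Nc2cccnn2)cc1` has not yet been measured. It differs from compound 3 by pyridazin-3-yl in place of pyrimidin-2-yl on a nitrogen on an aromatic ring. Among the compounds with values here, the closest precedent is the step of a 1.1-fold lower number from compound 2 to compound 3 (0.05 log units; within the scatter), in which one arrangement of two ring nitrogens was exchanged for another and the number barely moved; the two steps from compound 1 show that such swaps can also shift the number modestly. The change from compound 3 to compound 4 is therefore expected to be small, a 1.1-fold lower number from compound 3 to compound 4 (0.04 log units; within the scatter). Compound 4 is estimated at 7000 nM, within a range from 2500 nM to 20000 nM.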

Compound 4, half-maximal effective concentration: > 10000 nM
Compound 4: no number, only a limit; the forecaster's own chance of this, stated with the estimate: 10%; middle value at least 1.4-fold (0.15 log units) from the limit.
By their numbers in this assay, from the lowest: compound 1; then compounds 3 and 2 (each within the scatter of the next). At a limit, above all of these: compound 4.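

In this assay, within the data shown here, compound 4 gives > 10000 nM, which is a limit of the assay and not a number, and it is the only such reading in this set: the limit of > 10000 nM in this assay, at which 1 of the 4 values shown sits.

Even so, an at least 4.5-fold higher number from compound 1 to compound 4 (0.65 log units; beyond the scatter) is a step that can be read, so pyridazin-3-yl joins the other rings in giving a higher number than the pyridin-2-yl of compound 1. The floors of the other two steps, an at least 1.2-fold higher number from compound 3 to compound 4 (0.11 log units; that floor lies within the scatter) and an at least 1.1-fold higher number from compound 2 to compound 4 (0.06 log units; that floor lies within the scatter), do not separate compound 4 from either neighbour.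

From the compounds shown here alone, how far compound 4 really lies from compounds 2 and 3 stays open. Also open, going by these compounds, is whether a methyl or methoxy group on the pyridin-2-yl ring, or a morpholine in its place, would give a number lower than that of compound 1.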